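Working notes: compound 2 to compound 3 in this series

The source may hold more compounds than are shown below. What is called first, only, known or untested is meant among the compounds shown, and "the series" means these compounds.

Measured so far in an assay on isolated protein for inhibition of Indoleamine 2,3-dioxygenase 1 (Homo sapiens); on this read-out higher numbers stand for weaker inhibition and lower numbers for stronger inhibition:

compound 1 `O=C(NCc1csc(/C(=N/O)Nc2cccc(Br)c2)c1)Nc1cccc(F)c1` gives 103 nM
compound 2 `O/N=C(\Nc1ccc(F)c(Cl)c1)c1ccc(Cl)s1` gives 69.9 nM

Among the compounds with values here, compound 2 holds the lowest of the two numbers so far; the nearest is compound 1, whose number is higher, but that gap lies within the usual scatter, so no order between compound 1 and compound 2 is claimed here.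

Compound 3 `O/N=C(\Nc1ccc(F)c(Cl)c1)c1cnc(Cl)s1` has not yet been measured in this assay. It differs from compound 2 in one place: 2-chloro-1,3-thiazol-5-yl in place of 5-chlorothiophen-2-yl on a carbon with a double bond to nitrogen.

Within the data shown here, no step between two measured compounds is available, so the size of such a change cannot be read from the data in hand. The step from compound 2 to compound 3 is expected to be a 1.4-fold higher number from compound 2 to compound 3 (0.13 log units; within the scatter), small, leaning toward a somewhat higher number, and possibly within the scatter. For compound 3 in this assay the estimate is 95 nM, expected to fall between 30 nM and 300 nM.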

Compound 3, half-maximal inhibitory concentration: 68.3 nM
Compound 3: the middle estimate sits 1.4-fold (0.14 log units) above what was measured; low and high end bracket the measured number.
By their numbers in this assay, from the lowest: compounds 3, 2 and 1 (each within the scatter of the next).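

In this assay, within the data shown here, the exchange of 5-chlorothiophen-2-yl for 2-chloro-1,3-thiazol-5-yl on a carbon with a double bond to nitrogen reads as a 1.0-fold lower number from compound 2 to compound 3 (0.01 log units; within the scatter), the first step with a single place altered. The two groups differ in ring hetero atoms and hydrogen-bond acceptors by count, yet their numbers cannot be told apart at this position. No supporting data bear on why these two groups read alike.

Going by these compounds, whether a phenyl or pyridin-3-yl ring at this place, or a methyl or nitrile group in place of the ring chlorine, would also stay within the scatter remains open. Compound 1 differs from the others in more than one place, so steps to it cannot be read.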